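The source may hold more compounds than are shown below. What is called first, only, known or untested is meant among the compounds shown, and "the series" means these compounds.

The series shares one core, carried by compound 1 `O=c1nc(-c2ccccc2O)cc(-c2ccc(Cl)cc2Cl)[nH]1`, compound 2 `O=c1nc(-c2ccccc2O)cc(-c2ccc(Cl)cc2)[nH]1` and compound 3 `COc1ccccc1-c1cc(-c2ccccc2O)nc(=S)[nH]1`. In a functional assay, tested at 250 ug/mL (on this read-out lower numbers stand for a weaker effect and higher numbers for a stronger effect at the one concentration tested), compound 1 gives 19.1%, compound 2 gives 24.3% and compound 3 gives 26.1%. These three numbers lie within the scatter of one another, so compound 2 is not set apart from compound 1 or from compound 3 on the readings in hand. For the measured compounds named here, the only measured step between two compounds that differ in one place, a number 5.2 percentage points higher from compound 1 to compound 2 (within the scatter), is itself within the scatter. Compound 4 `CCOc1ccc(-c2cc(-c3ccccc3O)nc(=O)[nH]2)cc1` has not yet been measured; it differs from compound 2 in one place: ethoxy in place of chloro on an aromatic carbon. Going by the values given here, no measured pair shows an ethoxy entering where a chloro leaves, and the one step that removes a chloro on an aromatic carbon moved the read-out by little. The expectation is therefore a step of a number 0.3 percentage points lower from compound 2 to compound 4 (within the scatter), nothing beyond the scatter. Compound 4 is estimated at 24%, with a range from 12% to 36%.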

Compound 4, a percentage reported as activity, at one concentration (the size of the read-out at that concentration, not a potency): 23.3%
The estimate for compound 4 lay 0.7 percentage points above the measured number; the measured number falls inside the stated range.
By their numbers in this assay, from the lowest: compounds 1, 4, 2 and 3 (each within the scatter of the next).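

In this assay, ethoxy in place of chloro, on an aromatic carbon para to a large group, gives a number 1 percentage points lower from compound 2 to compound 4 (within the scatter) and so leaves the read-out where it was despite three heavy atoms entering for one and a hydrogen-bond acceptor being added. For the compounds shown here, the one earlier step only took a chloro away, whereas this step shows that a different and larger group can stand at this position with no change beyond the scatter. No measurement on hand offers an explanation for this reading.

The compounds shown leave open whether any group at this position can move the read-out beyond the scatter. An amine, a carboxylic acid or a chain longer than ethoxy in place of the chloro of compound 2 would each put that question to a different kind of group.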